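The source may hold more compounds than are shown below. What is called first, only, known or untested is meant among the compounds shown, and "the series" means these compounds.

Measured so far in a functional assay on MCF7 cells (Homo sapiens) for antiproliferative activity; on this read-out higher numbers stand for weaker inhibition and lower numbers for stronger inhibition:
- compound 1 `Cc1c(O)ccc2cc(-n3cc(-c4ccc(F)cc4F)nn3)c(=O)oc12`: 33500 nM
- compound 2 `CC(=O)Oc1ccc2cc(-n3cc(-c4ccc(F)cc4F)nn3)c(=O)oc2c1C`: a limit, > 100000 nM
- compound 3 `COc1ccc(-c2cn(C3Cc4ccc(O[C@@H]5OC(C)(C)[C@H](OC)[C@@H](O)[C@H]5O)c(C)c4OC3=O)nn2)cc1`: a limit, > 100000 nM

Going by the values given here, compound 1 is the only member of the series with a number in this assay. Compound 2 sits at a limit of the assay, not at a number. Compound 3 likewise sits at a limit. Among the compounds with values here, two of the three results therefore rest at the limit of > 100000 nM in this assay, at which 2 of the 3 values shown sit, and the one measured step, an at least 2.9-fold higher number from compound 1 to compound 2 (0.47 log units; beyond the scatter), only records that acetyl in place of hydrogen on an oxygen on an aromatic ring pushes the value out to that limit.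

Compound 4 `Cc1c(O)ccc2cc(-n3cc(/C=C/c4ccccc4)nn3)c(=O)oc12` keeps the core of compound 1 and changes the group on the five-membered aromatic ring: 2-phenylethenyl in place of 2,4-difluorophenyl on an aromatic carbon. Within the data shown here, no measured step touches this position; the step from compound 1 to compound 2 concerns the phenolic oxygen and says nothing about the substituent on the triazole. With no guidance either way, the expectation for compound 4 is a step of a 1.1-fold lower number from compound 1 to compound 4 (0.05 log units; within the scatter), i.e. no change beyond the scatter from compound 1. Compound 4 is thus estimated at 30000 nM, with a range from 8000 nM to 100000 nM, and a real chance that this assay returns only a limit for it.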

Compound 4, half-maximal inhibitory concentration: 33700 nM
For compound 4 the middle estimate is 1.1-fold (0.05 log units) below the measured one; the range from low to high includes it.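

In this assay, 2-phenylethenyl in place of 2,4-difluorophenyl on this aromatic carbon of the five-membered aromatic ring gives a 1.0-fold higher number from compound 1 to compound 4 (0.00 log units; within the scatter). Going by these compounds alone, this is the first reading at this position, and it shows that a swap removing both fluorine atoms and adding a double bond outside aromatic rings leaves the number within the scatter. Compound 4 returns a number and does not join the compounds at the limit: the limit of > 100000 nM in this assay, at which 2 of the 4 values shown sit.

Going by these compounds, both groups compared here end in a six-membered carbon ring and count no hydrogen-bond donors or acceptors, so it remains open whether an amine or a carboxylic acid at this position would shift the number beyond the scatter. On these data alone, it also remains open whether acetyl on the phenolic oxygen of compound 4 would behave as it does on compound 1.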